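The compounds below may be only part of what the source reports. "The series", "measured", "known", "first", "only" and "open" are said of these compounds alone.

Compound 1 `Cc1nnsc1CO/N=C/c1c(C)nn(C)c1Oc1ccc(F)cc1`: in a functional assay on PANC-1 cells (Homo sapiens) for inhibition, read by MTT assay, with a stated time of 48 h (on this read-out lower numbers stand for stronger inhibition and higher numbers for weaker inhibition), compound 1 gives > 50000 nM, which is a limit of the assay and not a number.
Compound 2 `Cc1nnsc1CO/N=C/c1c(C)nn(C)c1Oc1ccc(Br)cc1`: in this assay compound 2 gives 12800 nM.
Compound 3 `Cc1nnsc1CO/N=C/c1c(C)nn(C)c1Oc1ccc(OC(F)(F)F)cc1`: in this assay compound 3 gives > 50000 nM, again a limit of the assay rather than a number.

Compound 3 therefore stands at the edge of what this assay can report, and the whole set is shaped by the limit of > 50000 nM in this assay, at which 2 of the 3 values shown sit. Only compound 2, carrying bromo, gives a number at all.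

Compound 4 `Cc1nnsc1CO/N=C/c1c(C)nn(C)c1Oc1ccc(C(C)(C)C)cc1` differs from compound 3 in one place: tert-butyl in place of trifluoromethoxy on an aromatic carbon. Going by the values given here, two measured steps touch compound 3. The step of an at least 3.9-fold higher number from compound 2 to compound 3 (0.59 log units; beyond the scatter) shows that moving away from bromo pushed the number up to the limit. The step that the two limits leave unreadable from compound 1 to compound 3 compares two limits and says nothing about size. Among the compounds with values here, neither step involves tert-butyl, so no measured step reads directly on the change in hand; the one group that produced a number is bromo, and tert-butyl is simply a different group.

Within the data shown here, with compound 3 sitting at a limit, the only readable direction for compound 4 is downward or unchanged. The step of an at least 2.0-fold lower number from compound 3 to compound 4 (0.30 log units; that floor lies within the scatter) is therefore expected to be small and uncertain. Compound 4 is estimated at 25000 nM, with a likely range from 5000 nM to 100000 nM.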

Compound 4, half-maximal inhibitory concentration: > 50000 nM
Compound 4: no number, only a limit; the forecaster's own chance of this, stated with the estimate: 55%; at least 2.0-fold (0.30 log units) between middle value and limit.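

Replacing bromo with tert-butyl at this position gives an at least 3.9-fold higher number from compound 2 to compound 4 (0.59 log units; beyond the scatter) in this assay, so bromo remains the only group shown here that yields a number rather than a limit. Compound 4 also adds a new kind of group to the comparison: tert-butyl is built of carbon only, unlike fluoro, bromo and trifluoromethoxy, yet this change does not bring the compound back to a measurable value. The steps to compound 4 from compound 1 and from compound 3 cannot be read, as each joins two limits, and the series now rests mostly on one boundary of the assay: the limit of > 50000 nM in this assay, at which 3 of the 4 values shown sit.

As far as these compounds go, how compound 1, compound 3 and compound 4 rank against one another remains unknown, since all three stop at that same limit. It also remains open whether the measurable value of compound 2 is particular to bromo, as the compounds shown say nothing about chloro, iodo, an amine or a carboxylic acid at this position.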